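Chain Methyl Gain and Cytotoxicity at the Assay Limit

The compounds below may be only part of what the source reports. "The series", "measured", "known", "first", "only" and "open" are said of these compounds alone.

Measured compounds, with their values in an ADME assay on cells (Homo sapiens) for cytotoxicity; on this read-out higher numbers stand for lower toxicity in this test and lower numbers for higher toxicity in this test:
- Compound 1 `O=C1N(CCC(CCOc2ccc(-c3ccc(Cl)cc3)cc2)Cc2ccccc2)CCN1c1ccncc1`: in this assay compound 1 gives > 10000 nM, which is a limit of the assay.
- Compound 2 `CC(C)C(CCOc1ccc(-c2ccc(Cl)cc2)cc1)CCN1CCN(c2ccncc2)C1=O`: in this assay compound 2 gives > 25000 nM, also a limit.
- Compound 3 `CC(CCOc1ccc(-c2ccc(Cl)cc2)cc1)CCN1CCN(c2ccncc2)C1=O`: in this assay compound 3 gives > 25000 nM, again a limit.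

Compound 3 thus stands only at a limit, and the two other values shown are limits too, one at the limit of > 10000 nM in this assay, at which 1 of the 3 values shown sits, and two at the limit of > 25000 nM in this assay, at which 2 of the 3 values shown sit. Compound 4 `CCC(CCOc1ccc(-c2ccc(Cl)cc2)cc1)CCN1CCN(c2ccncc2)C1=O` differs from compound 3 by methyl in place of hydrogen on a saturated chain carbon, four bonds along the chain from an amide-type nitrogen in a ring and an oxygen on an aromatic ring. The measured steps that touch this chain carbon are a step that the two limits leave unreadable from compound 1 to compound 3, a step that the two limits leave unreadable from compound 1 to compound 2 and a step that the two limits leave unreadable from compound 2 to compound 3; none of them is readable in size, since every value involved is a limit. No step beyond the scatter can therefore be expected from the added methyl, and the step that the limit leaves unreadable from compound 3 to compound 4 is an estimate resting on these limits alone. Compound 4 is expected to give about 30000 nM in this assay, most likely again reported as a limit, within a range from 10000 nM to 100000 nM.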

Compound 4, half-maximal cytotoxic concentration: > 25000 nM
Compound 4 gave a limit, no number; the forecaster's own chance of this, stated with the estimate: 85%; the middle value lies beyond the limit too.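

Compound 4, like compound 1, compound 2 and compound 3, stands only at a limit in this assay, and none of its steps to these compounds can be read. The compounds shown leave open at what concentration any of them becomes cytotoxic, and whether the group on the chain carbon changes that concentration.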